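The source may report more compounds than this note shows. Statements on the series, on what has been measured and on what is new or still open speak of the compounds shown alone.

Compounds 1 and 2 share one core, with a methyl-bearing phenyl on the ring nitrogen. In an ADME assay on Vero cells (Chlorocebus sabaeus) for cytotoxicity (a higher number here means a weaker inhibitor, a lower number a stronger inhibitor), compound 1 `CCOC(=O)C1=C(C)N(c2ccccc2C)C(C)=C(C(=O)OCC)C1c1cn(-c2ccccc2)nc1-c1ccccc1` gives > 10 ug/mL, which is a limit of the assay and not a number. Compound 2 `CCOC(=O)C1=C(C)N(c2cccc(C)c2)C(C)=C(C(=O)OCC)C1c1cn(-c2ccccc2)nc1-c1ccccc1` gives > 10 ug/mL in this assay, again a limit. The step that the two limits leave unreadable from compound 1 to compound 2 is therefore unreadable, as the limit of > 10 ug/mL in this assay, at which 2 of the 3 values shown sit, shows. Compound 3 `CCOC(=O)C1=C(C)N(c2ccc(C)cc2)C(C)=C(C(=O)OCC)C1c1cn(-c2ccccc2)nc1-c1ccccc1` stands at "not determined" (no result reported) in this assay, so no number is known for it. Compound 4 `CCOC(=O)C1=C(C)N(c2ccccc2Cl)C(C)=C(C(=O)OCC)C1c1cn(-c2ccccc2)nc1-c1ccccc1` differs from compound 3 by 2-chlorophenyl in place of 4-methylphenyl on an amine nitrogen in a ring. Among the compounds with values here, no measured step bears on this change, and the two limits give no direction. Compound 4 is expected to give about 20 ug/mL in this assay, within a range from 8 ug/mL to 60 ug/mL, with a limit the likelier outcome.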

Compound 4, half-maximal inhibitory concentration: > 10 ug/mL
Compound 4 was reported as a limit; the forecaster's own chance of this, stated with the estimate: 75%; the middle value is on the limit's open side.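

No new step can be read between compound 1, compound 2 and compound 4 in this assay, because all three give a limit and not a number: the limit of > 10 ug/mL in this assay, at which 3 of the 4 values shown sit.

The compounds shown leave open whether changing the group on the ring nitrogen alters this read-out at all.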